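A few compounds are considered here, and "the series" means these few. Any claim that something is new, unique, unknown or untested is made for them only; others in the source may bear on it.

Measured compounds:
compound 1 `Cn1cnc2c(Nc3ccccc3)ncnc21`, 0%
compound 2 `Cn1cnc2c(Nc3ccc(F)cc3)ncnc21`, 8%
compound 3 `c1ccc(Cc2[nH]cnc3ncnc2-3)cc1`, 2%

In an assay on isolated protein for inhibition of Ca2+/calmodulin-dependent protein kinase II (CaM kinase II) (Rattus norvegicus), tested at 30 uM (on this read-out lower numbers stand for less inhibition and higher numbers for more inhibition at the one concentration tested (going by the name of the read-out)), compound 1 gives 0%, and compound 2, which carries fluoro in place of hydrogen on an aromatic carbon, gives 8%; the step of a number 8 percentage points higher from compound 1 to compound 2 (within the scatter) is small. Compound 3 rests on a different core, and the difference between the two cores is not broken down here. In this assay compound 3 gives 2%, close to the other two.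

Compound 4 `Fc1ccc(Cc2[nH]cnc3ncnc2-3)cc1` has not yet been measured. It differs from compound 3 by fluoro in place of hydrogen on an aromatic carbon, the same change that leads from compound 1 to compound 2. Because the earlier step of a number 8 percentage points higher from compound 1 to compound 2 (within the scatter) stayed within the scatter, the step from compound 3 to compound 4 is expected to be a number 3 percentage points higher from compound 3 to compound 4 (within the scatter) in this assay. Compound 4 is therefore estimated at 5%, most likely between 0% and 15%.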

Compound 4, a percentage reported as inhibition, at one concentration (the size of the read-out at that concentration, not a potency): 8%
The estimate for compound 4 lay 3 percentage points below the measured number; measured number inside the range.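

In this assay, fluoro in place of hydrogen on an aromatic carbon gives a number 6 percentage points higher from compound 3 to compound 4 (within the scatter) on the second core. Set beside the earlier step, the change reads the same on both cores: the same change on two cores in this assay, a number 8 percentage points higher (within the scatter) from compound 1 to compound 2 and a number 6 percentage points higher (within the scatter) from compound 3 to compound 4, 2 percentage points apart, within the scatter of two such steps. This shows that, in this small series, the change carries from one core to the other with no detectable difference, but since neither step leaves the scatter, it does not show that fluoro raises inhibition on either core.

The compounds shown leave open whether a different group on that ring, such as chloro, methoxy, an amine or a carboxylic acid, would move the number beyond the scatter. They also leave open how the change would behave on any further core.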